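Flipping one double bond: what to expect for compound 3

A few compounds are considered here, and "the series" means these few. Any claim that something is new, unique, unknown or untested is made for them only; others in the source may bear on it.

Compound 1 `CCOC(=O)c1cc(/C=C/c2c(Cl)ccc(C)c2F)on1`: > 128000 nM
Compound 2 `CCOC(=O)c1cc(/C=C\c2cc(F)cc(F)c2)on1`: > 128000 nM

Both entries come from an ADME assay on Vero cells (Chlorocebus sabaeus) for cytotoxicity, with a stated time of 72 h (on this read-out lower numbers stand for stronger inhibition and higher numbers for weaker inhibition), and neither is an exact number. Compound 2 gives > 128000 nM, which is a limit of the assay. For the measured compounds named here, on the numbers so far, compound 2 stands at the limit of > 128000 nM in this assay, at which 2 of the 2 values shown sit.

Compound 3 `CCOC(=O)c1cc(/C=C/c2cc(F)cc(F)c2)on1` has the same atoms and bonds as compound 2 and differs only in configuration as drawn: the two compounds have the same atoms and bonds and differ only in configuration as drawn: 1 of 1 stereo elements differ; a double bond is drawn Z in compound 2 and E in compound 3. Going by the values given here, no measured pair shows what such a change does in this assay, so no step beyond the usual scatter is expected, and another limit is the likeliest report. Compound 1, whose double bond is also drawn E, gives > 128000 nM, which is again a limit and supports this expectation. The expected change is small: a number no higher from compound 2 to compound 3 (the limit leaves the size open). For compound 3 the estimated value is 128000 nM, with an expected range of 60000 nM to 256000 nM.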

Compound 3, half-maximal inhibitory concentration: > 128000 nM
Compound 3: only a limit was reported (the forecaster's own chance of this, stated with the estimate: 85%); the middle value lies on the limit itself.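

Compound 2 and compound 3 differ only in how the double bond is drawn, yet no step can be read between them in this assay, because both give only a limit: the limit of > 128000 nM in this assay, at which 3 of the 3 values shown sit.

The compounds shown leave open whether flipping this double bond changes cytotoxicity at all, and at what concentration any of them would harm these cells.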